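A few compounds are considered here, and "the series" means these few. Any claim that something is new, unique, unknown or untested is made for them only; others in the source may bear on it.

Of the compounds shown here, two of a shared core have been measured. Compound 1 `Cc1cc(C(=O)N2CCC3(CC2)CC(=O)N(c2ccc(C(F)(F)F)cc2)C3)cc2cn[nH]c12` gives 8670 nM in a functional assay on HCT-116 cells (Homo sapiens) for antiproliferative activity, read by MTT assay, with a stated time of 48 h (on this read-out higher numbers stand for weaker inhibition and lower numbers for stronger inhibition), and compound 2 `O=C(c1ccc2[nH]c(-c3ccccc3)nc2c1)N1CCC2(CC1)CC(=O)N(c1ccc(C(F)(F)F)cc1)C2` gives 1220 nM. On these two numbers compound 2 stands lowest, with compound 1 higher by a gap beyond the scatter. Compound 3 `O=C(c1ccc2[nH]c(-c3ccco3)nc2c1)N1CCC2(CC1)CC(=O)N(c1ccc(C(F)(F)F)cc1)C2` carries one change from compound 2: furan-2-yl in place of phenyl on an aromatic carbon. Among the measured compounds shown here, no pair measured so far differs in one place, so the size of this step is unknown. Only a small step is expected, likely none beyond the scatter, in either direction a 1.3-fold higher number from compound 2 to compound 3 (0.12 log units; within the scatter). Because compound 2 shows 1220 nM, compound 3 is estimated at 1600 nM, within 600 nM to 4500 nM.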

Compound 3, half-maximal inhibitory concentration: > 10000 nM
Compound 3: no number, only a limit; the forecaster's own chance of this, stated with the estimate: 0%; middle value at least 6.2-fold (0.79 log units) from the limit.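

In this assay compound 3 gives > 10000 nM, which is a limit of the assay and not a number. Placing furan-2-yl in place of phenyl on this aromatic carbon, between two ring nitrogen atoms, gives an at least 8.1-fold higher number from compound 2 to compound 3 (0.91 log units; beyond the scatter), so this position is sensitive to the ring it carries, which the earlier compounds could not show. The full size of the step cannot be read: the limit of > 10000 nM in this assay, at which 1 of the 3 values shown sits.

Going by these compounds, it remains open whether the ring oxygen or the five-membered ring matters more. On these data alone, it is also open how a thiophene ring or an amine at this carbon would compare.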